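The compounds below may be only part of what the source reports. "The series", "measured", "known", "first", "only" and "open" are said of these compounds alone.

Measured so far in a functional assay on HepG2 cells (Homo sapiens) for antiproliferative activity, read by MTT assay, with a stated time of 24 h; a lower number here means a stronger inhibitor, a higher number a weaker inhibitor
- compound 1 `C#CCOc1ccc2c(=O)c(-c3cc(OC)c(OC)cc3OC)coc2c1` gives 4950 nM
- compound 2 `COc1cc(OC)c(-c2coc3cc(OCc4ccccc4F)ccc3c2=O)cc1OC` gives 1280 nM
- compound 3 `COc1cc(OC)c(-c2coc3cc(OCc4ccc(Br)cc4)ccc3c2=O)cc1OC` gives 1050 nM

Compound 3 shares the low end of this small set with compound 2, and the gap between them is a 1.2-fold lower number from compound 2 to compound 3 (0.09 log units; within the scatter). Replacing ethynyl with a substituted phenyl gave a 3.9-fold lower number from compound 1 to compound 2 (0.59 log units; beyond the scatter) and a 4.7-fold lower number from compound 1 to compound 3 (0.67 log units; beyond the scatter), so both modest steps lie beyond the scatter.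

The next compound is compound 4 `COc1cc(OC)c(-c2coc3cc(OCc4ccccc4C#N)ccc3c2=O)cc1OC`, and the change is 2-cyanophenyl in place of 4-bromophenyl on a saturated chain carbon bound to an oxygen on an aromatic ring. Among the measured compounds shown here, the closest precedent is the only exchange of one substituted phenyl for another, a 1.2-fold lower number from compound 2 to compound 3 (0.09 log units; within the scatter). The ethynyl steps involve a different kind of group and bear on this change less directly. For the measured compounds named here, no compound with a nitrile has been measured, so the range is kept wide.

In this assay no step beyond the scatter is expected, and the estimated step is a 1.1-fold higher number from compound 3 to compound 4 (0.06 log units; within the scatter). The estimated value for compound 4 is 1200 nM, with an expected range of 600 nM to 2500 nM.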

Compound 4, half-maximal inhibitory concentration: > 10000 nM
Compound 4 gave a limit, no number (the forecaster's own chance of this, stated with the estimate: 2%); middle value at least 8.3-fold (0.92 log units) away from the limit.
By their numbers in this assay, from the lowest: compounds 3 and 2 (each within the scatter of the next); then compound 1. At a limit, above all of these: compound 4.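

Compound 4 gives a limit in this assay, not a number: the limit of > 10000 nM in this assay, at which 1 of the 4 values shown sits.

Among the compounds shown here, the one earlier exchange of a substituted phenyl for another at this place stayed within the scatter, so that place looked tolerant, but an at least 9.5-fold higher number from compound 3 to compound 4 (0.97 log units; beyond the scatter), and the single change of cyano in place of fluoro on an aromatic carbon gives an at least 7.8-fold higher number from compound 2 to compound 4 (0.89 log units; beyond the scatter), so the choice of substituent on this phenyl can matter in this assay. Against the ethynyl compound, an at least 2.0-fold higher number from compound 1 to compound 4 (0.30 log units; that floor lies within the scatter), and this floor does not separate the two.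

From the compounds shown here alone, the true size of these steps stays open, as does whether the loss follows the nitrile itself or its place on the ring. A 4-cyanophenyl group would bear on that second question, while a 2-aminophenyl or 2-carboxyphenyl group would show how far the result extends to other groups.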